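Amide in place of the acid on the pyridine arm

The compounds below may be only part of what the source reports. "The series", "measured", "known", "first", "only" and "open" are said of these compounds alone.

Compound 3 `O=C(O)c1ccc(-c2cnc(C(=O)CCc3ccc(-c4ccccc4)cc3)o2)nc1` gives 14 nM in an assay for inhibition of Fatty-acid amide hydrolase 1 (Rattus norvegicus) (a lower number here means a stronger inhibitor, a higher number a weaker inhibitor), the highest number among the three measured compounds. Compound 1 `O=C(CCc1ccc(-c2ccccc2)cc1)c1ncc(-c2ccncc2)o1` gives 2.3 nM in this assay, and compound 2 `COC(=O)c1ccc(-c2cnc(C(=O)CCc3ccc(-c4ccccc4)cc3)o2)nc1` gives 2.2 nM; these two lie within the scatter of each other, as a 1.0-fold lower number from compound 1 to compound 2 (0.02 log units; within the scatter) shows. The carboxylic acid stands apart: a 6.1-fold higher number from compound 1 to compound 3 (0.78 log units; beyond the scatter), and a 6.4-fold higher number from compound 2 to compound 3 (0.80 log units; beyond the scatter).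

Compound 4 `NC(=O)c1cccc(-c2cnc(C(=O)CCc3ccc(-c4ccccc4)cc3)o2)n1` carries 6-carbamoylpyridin-2-yl in place of 5-carboxypyridin-2-yl on an aromatic carbon. Among the compounds with values here, the step that bears most directly on this change is a 6.4-fold higher number from compound 2 to compound 3 (0.80 log units; beyond the scatter), the one measured exchange of the group on the pyridine outside the ring; the carbamoyl group is also named at a different ring position than the carboxy group was, and no measured pair covers that move. With compound 1 and compound 2 both at the low end and only the acid high, the number is expected to come back down rather than rise further: a 3.1-fold lower number from compound 3 to compound 4 (0.49 log units; beyond the scatter) is expected, a drop beyond the scatter, though short of a full return to the level of the ester, because a 6.4-fold higher number from compound 2 to compound 3 (0.80 log units; beyond the scatter) was measured for the methyl ester and not for an amide. Compound 4 is therefore estimated at 4.5 nM, with a range of 1.5 nM to 14 nM.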

Compound 4, inhibition constant: 1.2 nM
Beside the measured number, compound 4's estimate is 3.8-fold (0.57 log units) above it; the measured number lies below the stated range.
By their numbers in this assay, from the lowest: compounds 4, 2 and 1 (each within the scatter of the next); then compound 3.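

Working from this assay, the exchange of 5-carboxypyridin-2-yl for 6-carbamoylpyridin-2-yl on this aromatic carbon gives a 12-fold lower number from compound 3 to compound 4 (1.07 log units; beyond the scatter) as a large step, even though the two groups have the same counts of heavy atoms, hydrogen-bond donors and hydrogen-bond acceptors. The new group also falls in with the two earlier low-number groups, with a 1.8-fold lower number from compound 2 to compound 4 (0.26 log units; within the scatter) and a 1.9-fold lower number from compound 1 to compound 4 (0.28 log units; within the scatter) placing pyridin-4-yl, 5-(methoxycarbonyl)pyridin-2-yl and 6-carbamoylpyridin-2-yl together; among the four compounds, compound 3 alone goes against this grouping. The data in hand offer no explanation for the size of the step or for this grouping.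

The step from compound 3 to compound 4 changes both the group on the pyridine and its named ring position, so the two contributions remain unseparated. A 5-carbamoylpyridin-2-yl group and a 6-carboxypyridin-2-yl group would divide them, and a 6-(methoxycarbonyl)pyridin-2-yl group or an N-methyl amide would show how widely the low numbers extend at this position.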